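The compounds below may be only part of what the source reports. "The series", "measured", "known", "first", "only" and "open" are said of these compounds alone.

Compounds and values in hand:

- Compound 1, `O=C(c1cc(Cl)ccc1-c1ncccn1)N1CC2(CC2)C[C@H]1CNc1ccc(C(F)(F)F)cn1`, gives 7.2.
- Compound 2, `Cc1cc(C)nc(NC[C@@H]2CC3(CC3)CN2C(=O)c2nc(C)sc2-c2ccccc2)n1`, gives 8.6.
- Compound 3, `Cc1ccc(-c2nccs2)c(C(=O)N2CC3(CC3)C[C@H]2CNc2ccc(C(F)(F)F)cn2)n1`, gives 8.

All three were read in a functional assay on HEK293 cells for antagonist activity at Orexin receptor type 2 (Homo sapiens), read by FLIPR and calcium flux; a lower number here means a less potent compound, a higher number a more potent compound, by a factor of ten per unit of this negative logarithm. Compound 2 stands highest of the three numbers; the nearest is compound 3, whose value in this assay is 8, a gap beyond the scatter, and the furthest is compound 1, whose value of 7.2 lies well below it. On these numbers compound 2 is the most potent compound of the set.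

The unmeasured compound 4, `Cc1cc(C(F)(F)F)cc(NC[C@@H]2CC3(CC3)CN2C(=O)c2nc(C)sc2-c2ccccc2)n1`, keeps everything of compound 2 except the group on the amine nitrogen: 6-methyl-4-(trifluoromethyl)pyridin-2-yl in place of 4,6-dimethylpyrimidin-2-yl on an amine nitrogen. For the measured compounds named here, no pair of measured compounds differs in this one place, so there is no measured step of this kind to lean on; the expectation rests only on the three values and on the change itself. The step from compound 2 to compound 4 in this assay is expected to be small, a slight fall if anything, and not beyond the scatter: a number 0.20 log units lower from compound 2 to compound 4 (within the scatter). Compound 4 is therefore estimated at 8.4 in this assay, with a range from 7.8 to 9.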

Compound 4, negative logarithm of the antagonist equilibrium constant: 8.6
Beside the measured number, compound 4's estimate is 0.20 log units below it, within the range that was stated.
By their numbers in this assay, from the lowest: compound 1; then compound 3; then compounds 2 and 4 (each within the scatter of the next).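

In this assay, for the compounds shown here, putting 6-methyl-4-(trifluoromethyl)pyridin-2-yl in place of 4,6-dimethylpyrimidin-2-yl on an amine nitrogen gives no change at the digits printed from compound 2 to compound 4 (within the scatter), the first reading of a change at this position alone, as the earlier compounds all differ in more than one place. The position thus accepts a ring with one hetero atom in place of two, and a group with more heavy atoms that carries fluorine, with no loss of potency beyond the scatter. Nothing measured here bears on why the two groups read alike.

The step changes the ring nitrogen count and the substituent together, so the compounds shown cannot separate the two, and a 4,6-dimethylpyridin-2-yl group would be needed to do so. They also leave open whether a saturated group such as cyclohexyl would be accepted on this amine nitrogen.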